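This account rests on a few compounds, and the source may have more. Where it says the series, first, only, none or still open, it means among the compounds named here.

Solubility series on the shared core. Compound 1 `O=C1O[C@@H](Cn2ccnc2)CN1c1ccc(-n2cc(-c3ccccn3)cn2)c(F)c1` in a physicochemical assay for solubility, read by HPLC, with a stated time of 24 h (on this read-out lower numbers stand for lower solubility and higher numbers for higher solubility), gives 12300 nM; compound 2 `NC(=O)[C@H]1CN(c2ccc(-n3cc(-c4ccccn4)cn3)c(F)c2)C(=O)O1` in this assay gives 27200 nM, the higher of the two numbers, with a 2.2-fold higher number from compound 1 to compound 2 (0.34 log units; beyond the scatter). Compound 3 `CONC(=O)[C@H]1CN(c2ccc(-n3cc(-c4ccccn4)cn3)c(F)c2)C(=O)O1` differs from compound 2 by methoxy in place of hydrogen on an amide-type nitrogen. Among the compounds with values here, no measured step alters the amide nitrogen, so the one step known, from compound 1 to compound 2, bears only loosely on this change. A step of at most modest size, in either direction, is expected for compound 3, as a 1.4-fold lower number from compound 2 to compound 3 (0.13 log units; within the scatter). Compound 3 in this assay is estimated at 20000 nM, within 8000 nM to 50000 nM.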

Compound 3, solubility: 78100 nM
Estimate against measurement, compound 3: 3.9-fold (0.59 log units) below; measured number above the stated range.
By their numbers in this assay, from the lowest: compound 1; then compound 2; then compound 3.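

Methoxy in place of hydrogen on an amide-type nitrogen gives a 2.9-fold higher number from compound 2 to compound 3 (0.46 log units; beyond the scatter) in this assay, so this nitrogen is a place where a substituent changes the read-out beyond the scatter. Methoxycarbamoyl in place of (1H-imidazol-1-yl)methyl on a saturated ring carbon gives a 6.3-fold higher number from compound 1 to compound 3 (0.80 log units; beyond the scatter), a wider span than the earlier carbamoyl step showed. Nothing given here accounts for the rise.

Open, from the compounds shown here alone, is whether a longer chain such as ethoxy, or an amine, on the amide-type nitrogen would give a number like that of compound 3. Also open, going by these compounds, is what a carboxylic acid in place of the carbamoyl group would give.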